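Adding a methyl group to compound 3

The source may hold more compounds than are shown below. What is called first, only, known or untested is meant among the compounds shown, and "the series" means these compounds.

In a functional assay on QGY-7703 cells (Homo sapiens) for cytotoxicity, read by MTT assay, with a stated time of 24 h (a lower number here means a stronger inhibitor, a higher number a weaker inhibitor), compound 3 `O=C1/C(=C/c2cccnc2)CN(S(=O)(=O)c2ccccc2)C/C1=C\c1ccccc1C(F)(F)F` gives 6240 nM. Compound 2 `O=C1/C(=C/c2cccnc2)CNC/C1=C\c1ccccc1C(F)(F)F` gives 3800 nM and compound 1 `Cc1ccc(S(=O)(=O)N2C/C(=C\c3cccnc3)C(=O)/C(=C/c3ccccc3F)C2)cc1` gives 9700 nM, and compound 3 lies within the scatter of each. Compound 4 `Cc1ccc(S(=O)(=O)N2C/C(=C\c3cccnc3)C(=O)/C(=C/c3ccccc3C(F)(F)F)C2)cc1` differs from compound 3 in one place: methyl in place of hydrogen on an aromatic carbon. This is methyl in place of hydrogen on an aromatic carbon, which turns phenylsulfonyl into (4-methylphenyl)sulfonyl. Within the data shown here, no measured step makes this exact change. The closest is a 1.6-fold higher number from compound 2 to compound 3 (0.22 log units; within the scatter), which brings in the phenylsulfonyl group itself and stays within the scatter. Compound 1 carries the (4-methylphenyl)sulfonyl group but has fluorine in place of trifluoromethyl, so it differs from compound 3 in two places. Compound 1 stands at 9700 nM, still within the scatter of compound 3. A change beyond the scatter is therefore not expected, and the expected step is a 1.1-fold higher number from compound 3 to compound 4 (0.05 log units; within the scatter). For compound 4 the estimated value is 7000 nM, with an expected range of 3500 nM to 14000 nM.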

Compound 4, half-maximal inhibitory concentration: 6170 nM
Estimate against measurement, compound 4: 1.1-fold (0.05 log units) above; low and high end bracket the measured number.
By their numbers in this assay, from the lowest: compounds 2, 4, 3 and 1 (each within the scatter of the next, the first and the last beyond it).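

In this assay, among these compounds, a 1.0-fold lower number from compound 3 to compound 4 (0.00 log units; within the scatter) gives the first direct reading of this change: methyl in place of hydrogen on an aromatic carbon, para to a large group, leaves the number within the scatter. Placing the whole (4-methylphenyl)sulfonyl group on the ring amine nitrogen gives a 1.6-fold higher number from compound 2 to compound 4 (0.21 log units; within the scatter), and trifluoromethyl in place of fluoro on an aromatic carbon gives a 1.6-fold lower number from compound 1 to compound 4 (0.20 log units; within the scatter), so neither of these single changes moves the number beyond the scatter. Nothing in the data given accounts for these results. As far as these compounds go, whether a methoxy group, an amine or a carboxylic acid on the same aromatic carbon would move the number beyond the scatter stays open. So does the effect of a methylsulfonyl group in place of (4-methylphenyl)sulfonyl on the ring nitrogen.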